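From phenyl to pyridin-4-yl on compound 3

The source may report more compounds than this note shows. Statements on the series, on what has been measured and on what is new or still open speak of the compounds shown alone.

Three compounds share one core and differ only in the aromatic group on an amine nitrogen in a ring. In an in vitro ADME assay on microsomes from liver (Homo sapiens) for metabolic stability (on this read-out higher numbers stand for fast clearance and lower numbers for slow clearance), compound 1 (`O=C(COCc1ccccc1)N1CCN(c2cccc(Cl)c2)CC1`) gives 310 mL.min-1.g-1, compound 2 (`O=C(COCc1ccccc1)N1CCN(c2ccc(F)cc2F)CC1`) gives 580 mL.min-1.g-1, and compound 3 (`O=C(COCc1ccccc1)N1CCN(c2cc(Cl)ccn2)CC1`) gives 130 mL.min-1.g-1, the lowest of the three numbers. The first two values do not separate, with a 1.9-fold higher number from compound 1 to compound 2 (0.27 log units; within the scatter).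

Compound 4 (`O=C(COCc1ccncc1)N1CCN(c2cc(Cl)ccn2)CC1`) keeps the 4-chloropyridin-2-yl group of compound 3 but has pyridin-4-yl in place of phenyl on a saturated chain carbon bound to an oxygen on a saturated carbon.

Within the data shown here, no measured step changes this place. The closest guides are the two steps that put 4-chloropyridin-2-yl in place of a phenyl group on the amine nitrogen in a ring. They are a 2.4-fold lower number from compound 1 to compound 3 (0.38 log units; beyond the scatter) and a 4.5-fold lower number from compound 2 to compound 3 (0.65 log units; beyond the scatter), both modest. Those steps happened elsewhere in the molecule, so they carry over only loosely. A modest move to a lower number is therefore expected in this assay, an estimated 2.2-fold lower number from compound 3 to compound 4 (0.34 log units; beyond the scatter). For compound 4 the expected value is 60 mL.min-1.g-1, with an estimated range from 25 mL.min-1.g-1 to 130 mL.min-1.g-1.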

Compound 4, intrinsic clearance in microsomes: 4 mL.min-1.g-1
Compound 4: the middle estimate sits 15-fold (1.18 log units) above what was measured; measured number outside the range, below it.
By their numbers in this assay, from the lowest: compound 4; then compound 3; then compounds 1 and 2 (each within the scatter of the next).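

Until compound 4, every change sat on the amine nitrogen in a ring, so the far end of the molecule, on a saturated chain carbon bound to an oxygen on a saturated carbon, had stayed untested. In this assay, among these compounds, this end turns out to matter more than the group on that nitrogen: pyridin-4-yl in place of phenyl gives a 33-fold lower number from compound 3 to compound 4 (1.51 log units; beyond the scatter) and is the largest step, even though only one ring carbon gives way to a nitrogen, adding one hydrogen-bond acceptor with no change in heavy-atom count. Nothing in the available data explains why this single swap has such a large effect.

Going by these compounds, this step rests on one pair of compounds, both carrying the 4-chloropyridin-2-yl group, so it remains open whether the same swap would give a step of similar size with the 3-chlorophenyl group of compound 1 or the 2,4-difluorophenyl group of compound 2. Also open, on these data alone, is how other rings at this place, such as pyridin-3-yl, pyridin-2-yl or pyrimidin-5-yl, would compare with pyridin-4-yl.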